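Moving the hydroxyl on the ring beside the nitrogen

The source may report more compounds than this note shows. Statements on the series, on what has been measured and on what is new or still open speak of the compounds shown alone.

Compound 1, `Oc1cccc(-c2cc(-c3cccc(O)c3)nc(-c3ccccc3O)c2)c1`, in a functional assay on DU-145 cells (Homo sapiens) for cytotoxicity, read by CCK-8 assay, with a stated time of 4 days (on this read-out higher numbers stand for weaker inhibition and lower numbers for stronger inhibition), gives a limit of > 50000 nM and no number.
Compound 2, `Oc1ccc(-c2cc(-c3cccc(O)c3)cc(-c3cccc(O)c3)n2)cc1`, gives 1940 nM.
Compound 3, `Oc1ccc(-c2cc(-c3cccc(O)c3)cc(-c3ccc(O)cc3)n2)cc1`, gives 1400 nM.

Compound 3 holds the lowest of the two numbers in this assay, yet compound 2 sits within the scatter of it, so no order between the two can be read. Compound 4, `Oc1ccc(-c2cc(-c3cccc(O)c3)cc(-c3ccccc3O)n2)cc1`, has not been measured; it differs from compound 3 by 2-hydroxyphenyl in place of 4-hydroxyphenyl on an aromatic carbon.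

Going by the values given here, one measured step bears on this change directly and runs the opposite way: an at least 25-fold lower number from compound 1 to compound 2 (1.41 log units; beyond the scatter), a step that was bounded by the limit of > 50000 nM in this assay, at which 1 of the 3 values shown sits. The other step, a 1.4-fold lower number from compound 2 to compound 3 (0.14 log units; within the scatter), touched a different ring and stayed within the scatter, so it gives little guidance. A 2-hydroxyphenyl returning to the carbon next to the ring nitrogen is therefore expected to raise the number by a large margin, with a real chance that this assay again reports only a limit.

Compound 4 is estimated at 40000 nM, with a range from 8000 nM to 200000 nM, which would mean an expected step of a 29-fold higher number from compound 3 to compound 4 (1.46 log units; beyond the scatter).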

Compound 4, half-maximal inhibitory concentration: > 50000 nM
Compound 4 gave a limit, no number (the forecaster's own chance of this, stated with the estimate: 55%); middle value at least 1.2-fold (0.09 log units) from the limit.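

In this assay, the loss tied to a 2-hydroxyphenyl group on the aromatic carbon next to the ring nitrogen now appears against two other placements of the hydroxyl on that ring: the 4-hydroxyphenyl group gives an at least 35-fold higher number from compound 3 to compound 4 (1.55 log units; beyond the scatter), and the 3-hydroxyphenyl group gives an at least 25-fold higher number from compound 2 to compound 4 (1.41 log units; beyond the scatter). Going by these compounds alone, until now the only step at this carbon had been the one on the core of compound 1, so a single pair carried the whole observation. With compound 4, the same swap has been seen on a second core, with a loss of similar reach on both: the same change on two cores in this assay, an at least 25-fold lower number (1.41 log units; beyond the scatter) from compound 1 to compound 2 and an at least 35-fold lower number (1.55 log units; beyond the scatter) from compound 4 to compound 3; the limit leaves it open whether they differ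

As far as these compounds go, the two limits leave the step between compound 1 and compound 4 unreadable, and how far either compound lies past the top of the assay stays unknown: the limit of > 50000 nM in this assay, at which 2 of the 4 values shown sit. It also remains open whether the hydroxyl itself sets this loss, or whether a 2-methoxyphenyl or a 2-aminophenyl group on the same carbon would fall to a limit as well.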